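This account rests on a few compounds, and the source may have more. Where it says the series, first, only, none or still open, it means among the compounds named here.

Of the compounds shown here, two have been measured so far. In a physicochemical assay for lipophilicity, read by HPLC, measured as chromatographic lipophilicity, at pH 7.4 (a higher number here means a more lipophilic compound, a lower number a more polar compound), compound 1 (`O=C(C1CCN(c2ncccn2)CC1)N1N=CC[C@H]1c1ccccc1`) gives 4.7 and compound 2 (`O=C(C1CCN(C(=O)C(F)(F)F)CC1)N1N=CCC1c1ccccc1`) gives 4.9 on the same scale, so these two numbers lie within the usual scatter of each other. Compound 3 (`O=C(c1cocn1)N1CCC(C(=O)N2N=CCC2c2ccccc2)CC1`) differs from compound 2 at one place (1,3-oxazol-4-yl in place of trifluoromethyl on a carbonyl carbon): 1,3-oxazol-4-yl in place of trifluoromethyl on a carbonyl carbon. For the measured compounds named here, no measured pair shows this change, so the expectation rests on the structural change alone. A lower number is expected, with an estimated step of a number 0.80 log units lower from compound 2 to compound 3 (beyond the scatter) that would lie beyond the scatter. Compound 3 is estimated at 4.1 (expected range 3.6 to 4.6).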

Compound 3, distribution coefficient: 2.9
Estimate against measurement, compound 3: 1.20 log units above; the whole stated range lies above it.
By their numbers in this assay, from the lowest: compound 3; then compounds 1 and 2 (each within the scatter of the next).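

In this assay, for the compounds shown here, 1,3-oxazol-4-yl in place of trifluoromethyl on a carbonyl carbon gives a number 2.00 log units lower from compound 2 to compound 3 (beyond the scatter) and so provides the first measured step at this position. The group on this carbonyl carbon can therefore shift the reading well beyond the scatter. Nothing shown here accounts for the size of this step.

This single pair cannot tell whether the ring, its hetero atoms or the loss of fluorine matters most. Going by these compounds, whether a methyl group or a furan ring on the same carbonyl carbon would give a similar step remains open.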